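A few compounds are considered here, and "the series" means these few. Any claim that something is new, unique, unknown or untested is made for them only; others in the source may bear on it.

Series on the shared core of compound 1 `O=c1oc(Nc2ccccc2I)nc2ccccc12`, which in an assay on isolated protein for inhibition of complement C1r subcomponent (Homo sapiens) (a higher number here means a weaker inhibitor, a lower number a stronger inhibitor), gives 3500 nM. Compound 2 `Cc1ccccc1Nc1nc2ccccc2c(=O)o1` carries a methyl in place of the iodo, and in this assay compound 2 gives 31000 nM; this is the higher of the two numbers recorded so far, the gap being an 8.9-fold higher number from compound 1 to compound 2 (0.95 log units; beyond the scatter). The next member is compound 3 `Cc1cccc(C)c1Nc1nc2ccccc2c(=O)o1`, which differs from compound 2 by methyl in place of hydrogen on an aromatic carbon. Among the measured compounds shown here, no measured step concerns this exact change: the one step recorded, an 8.9-fold higher number from compound 1 to compound 2 (0.95 log units; beyond the scatter), swapped one group for another rather than adding a methyl to an otherwise unchanged ring, so it shows only that alterations on this ring register in this assay at modest size, not in which direction a second methyl would move the number. The working expectation for compound 3 is therefore a step of a 1.2-fold lower number from compound 2 to compound 3 (0.09 log units; within the scatter), smaller than that recorded step and uncertain in sign. Compound 3 is expected to give about 25000 nM in this assay, within 8000 nM to 80000 nM.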

Compound 3, half-maximal inhibitory concentration: > 62500 nM
Compound 3: a limit, no number (the forecaster's own chance of this, stated with the estimate: 15%); middle value at least 2.5-fold (0.39 log units) from the limit.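

For compound 3 the reading in this assay is a limit of the assay and not a number: the limit of > 62500 nM in this assay, at which 1 of the 3 values shown sits. Among the compounds shown here, the change of methyl in place of hydrogen on an aromatic carbon, here ortho to a large group and meta to a methyl group, gives an at least 2.0-fold higher number from compound 2 to compound 3 (0.30 log units; that floor lies within the scatter), and this is the first step that adds a group to an otherwise unchanged ring rather than swapping one group for another. It gives that addition a direction that the earlier swap could not, since the number does not come down with the added methyl, but the floor of the step lies within the scatter and its true size cannot be read.

From the compounds shown here alone, how far compound 3 lies past its limit stays open, so the size of this step remains unknown and cannot be set against an 8.9-fold higher number from compound 1 to compound 2 (0.95 log units; beyond the scatter). Also open is how other groups on this ring would read in this assay, such as an amine, a carboxylic acid, a methoxy group or a longer chain, as the compounds shown carry only iodo and methyl there.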